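Swapping nitro for methoxycarbonyl on the pendant phenyl ring

The source may report more compounds than this note shows. Statements on the series, on what has been measured and on what is new or still open speak of the compounds shown alone.

Compound 3 `CC(C)c1cccc(C(C)C)c1NC(=O)NCC1(c2cccc([N+](=O)[O-])c2)CCCC1` gives 51 nM in an assay on microsomes for inhibition of acyl-CoA:cholesterol acyltransferase (Oryctolagus cuniculus) (a lower number here means a stronger inhibitor, a higher number a weaker inhibitor), the highest of the three numbers recorded; compound 2 `CC(C)c1cccc(C(C)C)c1NC(=O)NCC1(c2ccc(Cl)cc2)CCCC1` gives 32 nM and compound 1 `Cc1ccc(C2(CNC(=O)Nc3c(C(C)C)cccc3C(C)C)CCCC2)cc1` gives 25 nM. The differences among them are small: a 2.0-fold higher number from compound 1 to compound 3 (0.31 log units; beyond the scatter) and a 1.6-fold higher number from compound 2 to compound 3 (0.20 log units; within the scatter), while a 1.3-fold higher number from compound 1 to compound 2 (0.11 log units; within the scatter). Compound 4 `COC(=O)c1cccc(C2(CNC(=O)Nc3c(C(C)C)cccc3C(C)C)CCCC2)c1` differs from compound 3 by methoxycarbonyl in place of nitro on an aromatic carbon. Going by the values given here, no measured step exchanges nitro for methoxycarbonyl, but every change on this phenyl ring so far has moved this assay only a little, so a similarly small shift is expected here. The expected step is a 1.0-fold lower number from compound 3 to compound 4 (0.01 log units; within the scatter), not beyond the scatter. Compound 4 is accordingly estimated at 50 nM, within a range from 20 nM to 125 nM.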

Compound 4, half-maximal inhibitory concentration: 34 nM
The estimate for compound 4 lay 1.5-fold (0.17 log units) above the measured number; low and high end bracket the measured number.
By their numbers in this assay, from the lowest: compounds 1, 2, 4 and 3 (each within the scatter of the next, the first and the last beyond it).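

In this assay, methoxycarbonyl on this aromatic carbon stays within the scatter of every earlier compound: a 1.5-fold lower number from compound 3 to compound 4 (0.18 log units; within the scatter), a 1.1-fold higher number from compound 2 to compound 4 (0.03 log units; within the scatter) and a 1.4-fold higher number from compound 1 to compound 4 (0.13 log units; within the scatter). Compound 4 therefore shows that 3-(methoxycarbonyl)phenyl, with 4 heavy atoms against 3 in nitro, fits the same narrow band of numbers, and unlike compound 3 it is not separated from compound 1 beyond the scatter. No measured evidence here bears on the reason for this. Going by these compounds, whether a carboxylic acid, an amine or a longer ester chain on this carbon would stay within that band remains open.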